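Moving a Chlorine Again: Does the Step Repeat?

The source may hold more compounds than are shown below. What is called first, only, known or untested is meant among the compounds shown, and "the series" means these compounds.

Measured in an ADME assay on THP-1 cells (Homo sapiens) for inhibition, read by MTT assay, with a stated time of 48 h; a higher number here means a weaker inhibitor of growth, a lower number a stronger inhibitor of growth:
Compound 1 `Clc1ccc(Cn2cc(COc3ccccc3)nn2)cc1` gives 36.4 ug/mL.
Compound 2 `Clc1cccc(Cn2cc(COc3ccccc3)nn2)c1` gives 14.6 ug/mL.
Compound 3 `Clc1ccc(Cn2cc(COc3ccc(Cl)cc3)nn2)cc1` gives 17.4 ug/mL.

Compound 2 differs from compound 1 by 3-chlorophenyl in place of 4-chlorophenyl on a saturated chain carbon bound to an aromatic nitrogen; this change gave a 2.5-fold lower number from compound 1 to compound 2 (0.40 log units; beyond the scatter). Compound 3 differs from compound 1 by chloro in place of hydrogen on an aromatic carbon, a change that gave a 2.1-fold lower number from compound 1 to compound 3 (0.32 log units; beyond the scatter). Compound 4 `Clc1ccc(OCc2cn(Cc3cccc(Cl)c3)nn2)cc1` has not been measured. It differs from compound 3 by 3-chlorophenyl in place of 4-chlorophenyl on a saturated chain carbon bound to an aromatic nitrogen, the same change as that from compound 1 to compound 2, here made on the core of compound 3, which carries the added chloro. Because a 2.5-fold lower number from compound 1 to compound 2 (0.40 log units; beyond the scatter) was a modest step beyond the scatter, a step of similar size is expected for compound 4, a 2.2-fold lower number from compound 3 to compound 4 (0.34 log units; beyond the scatter). This rests on one earlier example only, so the expectation is loose. Compound 4 is estimated at 8 ug/mL, most likely between 4 ug/mL and 16 ug/mL.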

Compound 4, concentration for 50% growth inhibition: 20.9 ug/mL
Beside the measured number, compound 4's estimate is 2.6-fold (0.42 log units) below it, outside the stated range (above it).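

In this assay, the change to 3-chlorophenyl in place of 4-chlorophenyl did not carry over to the core with the added chloro, giving a 1.2-fold higher number from compound 3 to compound 4 (0.08 log units; within the scatter), and the two steps differ: the same change on two cores in this assay, a 2.5-fold lower number (0.40 log units; beyond the scatter) from compound 1 to compound 2 and a 1.2-fold higher number (0.08 log units; within the scatter) from compound 3 to compound 4, 3.0-fold (0.48 log units) apart, beyond the scatter of two such steps Adding the chloro on an aromatic carbon also behaved differently on the second core, giving a 1.4-fold higher number from compound 2 to compound 4 (0.16 log units; within the scatter), and again the steps differ: the same change on two cores in this assay, a 2.1-fold lower number (0.32 log units; beyond the scatter) from compound 1 to compound 3 and a 1.4-fold higher number (0.16 log units; within the scatter) from compound 2 to compound 4, 3.0-fold (0.48 log units) apart, beyond the scatter of two such steps In these four compounds, the effect of each chlorine change depended on the core, so neither step can be carried across unchanged, but this single set does not show why or whether the pattern extends to other compounds.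

The compounds shown leave open how a methoxy group or an amine would behave in place of a chloro. They also leave open whether a longer chain would alter these steps.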